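The source may report more compounds than this note shows. Statements on the series, on what has been measured and on what is new or still open speak of the compounds shown alone.

Compound 1 `CC1(C)O[C@H]2[C@H](OCc3noc(-c4ccc([N+](=O)[O-])cc4)n3)O[C@H](CSc3ncn[nH]3)[C@H]2O1` carries a ((1H-1,2,4-triazol-5-yl)sulfanyl)methyl group on the shared core. In a functional assay on WiDr cells (Homo sapiens) for antiproliferative activity, read by sulforhodamine B assay, with a stated time of 48 h (a lower number here means a stronger inhibitor of growth, a higher number a weaker inhibitor of growth), compound 1 gives only > 100000 nM, which is a limit of the assay rather than a measured number. Compound 2 `CC(=O)OC[C@H]1O[C@@H](OCc2noc(-c3ccc([N+](=O)[O-])cc3)n2)[C@@H]2OC3(CCCC3)O[C@@H]21` is a related compound; in this assay compound 2 gives 36000 nM. Among the two values shown, compound 1 stands at the limit of > 100000 nM in this assay, at which 1 of the 2 values shown sits, the weak end of what can be measured. Compound 3 `CC1(C)O[C@H]2[C@H](OCc3noc(-c4ccc([N+](=O)[O-])cc4)n3)O[C@H](CO)[C@H]2O1` differs from compound 1 by hydroxy in place of (1H-1,2,4-triazol-5-yl)sulfanyl on a saturated chain carbon bound to a saturated ring carbon. For the measured compounds named here, no measured pair shows the effect of this change, and the step of an at least 1.2-fold lower number from compound 1 to compound 3 (0.09 log units; that floor lies within the scatter) is expected to stay within the usual scatter. Compound 3 is therefore expected to give about 80000 nM in this assay, with a likely range from 20000 nM to 300000 nM, and with a fair chance that only a limit is reported again.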

Compound 3, concentration for 50% growth inhibition: > 100000 nM
Compound 3: only a limit was reported (the forecaster's own chance of this, stated with the estimate: 55%); middle value at least 1.2-fold (0.09 log units) from the limit.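

No step can be read from compound 1 to compound 3, because both results are limits and not measured numbers: the limit of > 100000 nM in this assay, at which 2 of the 3 values shown sit.

The compounds shown leave open whether hydroxy in place of (1H-1,2,4-triazol-5-yl)sulfanyl changes growth inhibition at all, and in which direction.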